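The source may report more compounds than this note shows. Statements on the series, on what has been measured and on what is new or still open speak of the compounds shown alone.

In a functional assay on the whole organism (strain albino) with Rattus norvegicus as the target, read by paw edema, with stated times of 1 h and 4 h, at a dose of 25 mg/kg by the oral route (a higher number here means a stronger effect of the compound at the dose given, a lower number a weaker effect), the measured compounds stand as follows:
compound 1, `COc1ccc(Cl)cc1C(=O)Nc1ccc(C2=NN(c3ccccc3)C(c3ccccc3[N+](=O)[O-])C2)cc1`: 80.2%
compound 2, `COc1ccc(Cl)cc1C(=O)Nc1ccc(C2=NNC(c3ccccc3[N+](=O)[O-])C2)cc1`: 88.3%
compound 3, `COc1ccc(C2CC(c3ccc(NC(=O)c4cc(Cl)ccc4OC)cc3)=NN2C(C)=O)cc1`: 86%

Compound 3 sits between compound 2 and compound 1 on these numbers, and both gaps are within the scatter. Compound 4 is `COc1ccc(Cl)cc1C(=O)Nc1ccc(C2=NN(C(C)=O)C(c3ccccc3[N+](=O)[O-])C2)cc1`; against compound 3 the change is 2-nitrophenyl in place of 4-methoxyphenyl on a saturated ring carbon. Going by the values given here, the only measured step, a number 8.1 percentage points higher from compound 1 to compound 2 (within the scatter), concerns the ring nitrogen and not this carbon, so no measured step bears directly on the change. The three measured values, two of them with the 2-nitrophenyl and one with the 4-methoxyphenyl, all lie within the scatter of one another, so no step beyond the scatter is expected here: a number 1 percentage points lower from compound 3 to compound 4 (within the scatter) is the estimated step. Compound 4 is expected to give 85%, within 72% to 95%.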

Compound 4, a percentage reported as activity, at one dose (the size of the read-out at that dose, not a potency): 92.2%
Estimate against measurement, compound 4: 7.2 percentage points below; measured number inside the range.
By their numbers in this assay, from the lowest: compounds 1, 3, 2 and 4 (each within the scatter of the next, the first and the last beyond it).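

Going by these compounds alone, with 2-nitrophenyl in place of 4-methoxyphenyl on the saturated ring carbon, a number 6.2 percentage points higher from compound 3 to compound 4 (within the scatter) is the first direct reading at this position in this assay and leaves the two groups unseparated. Within the data shown here, on the amine nitrogen in the ring, acetyl in place of hydrogen gives a number 3.9 percentage points higher from compound 2 to compound 4 (within the scatter) while acetyl in place of phenyl gives a number 12 percentage points higher from compound 1 to compound 4 (beyond the scatter) and is the only new step to clear the scatter. No measurement shown accounts for these steps.

Open, as far as these compounds go, is whether an amine or a carboxylic acid on the aromatic ring at this carbon, or a longer chain in place of acetyl on the ring nitrogen, would shift the read-out.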